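One Ring Substituent Changes on a Shared Core

The source may report more compounds than this note shows. Statements on the series, on what has been measured and on what is new or still open speak of the compounds shown alone.

Three compounds share a core and differ only in one aromatic group. Compound 1 `O=C(O)Cc1sc(C(c2ccc(F)cc2)c2ccc(F)cc2)nc1-c1cc(F)cc(F)c1` gives 35 nM in an in vitro assay on HEK385-7 cells for displacement of a labelled ligand from prostaglandin D2 receptor 2 (Homo sapiens); on this read-out lower numbers stand for stronger inhibition and higher numbers for weaker inhibition. Compound 2 `N#Cc1ccc(-c2nc(C(c3ccc(F)cc3)c3ccc(F)cc3)sc2CC(=O)O)cc1` gives 150 nM, and compound 3 `O=C(O)Cc1sc(C(c2ccc(F)cc2)c2ccc(F)cc2)nc1-c1ccnc(O)c1` gives 68 nM. Compound 3 therefore holds the second highest of the three numbers: the step of a 1.9-fold higher number from compound 1 to compound 3 (0.29 log units; within the scatter) lies within the scatter, while the step of a 2.2-fold lower number from compound 2 to compound 3 (0.34 log units; beyond the scatter) is beyond it.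

Compound 4 `Cc1cc(-c2nc(C(c3ccc(F)cc3)c3ccc(F)cc3)sc2CC(=O)O)cnc1N` carries the same core with 6-amino-5-methylpyridin-3-yl in place of 2-hydroxypyridin-4-yl on an aromatic carbon. Among the compounds with values here, the steps that bear on this change all swap the group at this same position: a 4.3-fold higher number from compound 1 to compound 2 (0.63 log units; beyond the scatter), a 1.9-fold higher number from compound 1 to compound 3 (0.29 log units; within the scatter) and a 2.2-fold lower number from compound 2 to compound 3 (0.34 log units; beyond the scatter). None of them is large, so another group of the same kind, one six-membered aromatic ring with 1 hetero atom, 1 hydrogen-bond donor and 2 hydrogen-bond acceptors, is expected to move this assay only modestly, if at all.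

Compound 4 is therefore expected to give about 60 nM, with a range from 20 nM to 200 nM. This estimate means a step of a 1.1-fold lower number from compound 3 to compound 4 (0.05 log units; within the scatter), expected to stay within the usual scatter.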

Compound 4, half-maximal inhibitory concentration: 880 nM
Estimate against measurement, compound 4: 15-fold (1.17 log units) below, outside the stated range (above it).
By their numbers in this assay, from the lowest: compounds 1 and 3 (each within the scatter of the next); then compound 2; then compound 4.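

Within the data shown here, this position tolerates less than the earlier compounds suggested. In this assay, the large step of a 13-fold higher number from compound 3 to compound 4 (1.11 log units; beyond the scatter) joins two groups with the same kind of ring, the same hydrogen-bond donor and acceptor counts and no net charge, so those counts alone do not predict the outcome at this position. The other two comparisons point the same way, with a 5.9-fold higher number from compound 2 to compound 4 (0.77 log units; beyond the scatter) and a 25-fold higher number from compound 1 to compound 4 (1.40 log units; beyond the scatter), which makes compound 4 the weakest of the four, with all three steps beyond the scatter.

The data shown offer no measured explanation for this loss. On these data alone, compound 4 brings in an amine and a methyl group together, so it remains open which of them matters, and 6-aminopyridin-3-yl or 5-methylpyridin-3-yl at this position would separate the two.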